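Moving the ring nitrogen in a methylpyridyl tetrazole series

A few compounds are considered here, and "the series" means these few. Any claim that something is new, unique, unknown or untested is made for them only; others in the source may bear on it.

Measured so far:
compound 1 `N#Cc1ccccc1-c1cc(F)cc(-n2nnc(-c3ccccn3)n2)c1` — 4 nM
compound 2 `Cc1cccnc1-c1cc(F)cc(-n2nnc(-c3ccccn3)n2)c1` — 24 nM

In an assay for binding affinity to metabotropic glutamate receptor 5 (Rattus norvegicus) (a higher number here means a weaker inhibitor, a lower number a stronger inhibitor), compound 1 gives 4 nM, and compound 2 gives 24 nM. Among the compounds with values here, compound 2 thus stands as the higher of the two numbers in this assay, with the only step toward it being a 6.0-fold higher number from compound 1 to compound 2 (0.78 log units; beyond the scatter).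

Compound 3 `Cc1cnccc1-c1cc(F)cc(-n2nnc(-c3ccccn3)n2)c1` keeps the same atoms as compound 2 but joins them differently: 3-methylpyridin-4-yl in place of 3-methylpyridin-2-yl on an aromatic carbon. Within the data shown here, no measured step exchanges one methylpyridyl for another, so the single step that bears on it, from compound 1 to compound 2, replaced the whole group rather than moving its nitrogen and offers only an indirect guide to the size of the change. The expected step for compound 3 is therefore modest, a 1.6-fold lower number from compound 2 to compound 3 (0.20 log units; within the scatter), with a wide range in either direction. Compound 3 is estimated at 15 nM, between 4 nM and 60 nM.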

Compound 3, inhibition constant: 33 nM
Estimate against measurement, compound 3: 2.2-fold (0.34 log units) below, and the stated range covers the measured number.
By their numbers in this assay, from the lowest: compound 1; then compounds 2 and 3 (each within the scatter of the next).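

In this assay, placing 3-methylpyridin-4-yl where 3-methylpyridin-2-yl stood gives a 1.4-fold higher number from compound 2 to compound 3 (0.14 log units; within the scatter) and so, on this aromatic carbon, these two placements of the ring nitrogen are not told apart. The gap to the nitrile-bearing compound persists with the new isomer, since 3-methylpyridin-4-yl in place of 2-cyanophenyl gives an 8.3-fold higher number from compound 1 to compound 3 (0.92 log units; beyond the scatter) and thus the weaker binding seen earlier for 3-methylpyridin-2-yl is not confined to that one methylpyridyl group. Nothing available here accounts for either step.

The compounds shown leave open whether a methoxy group or a chlorine atom in place of the methyl would bring either pyridine closer to compound 1. They also leave open what a nitrile on the pyridine ring, in place of the methyl, would do in this assay.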